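Trifluoroacetyl in place of the fluorinated carbamate on the piperidine

The compounds below may be only part of what the source reports. "The series", "measured", "known", "first", "only" and "open" are said of these compounds alone.

Compound 2 `Cc1nc(S(C)(=O)=O)ccc1Oc1ncnc(OC2CCN(C(=O)O[C@@H](C)CF)CC2)c1F` gives 1680 nM in a functional assay on isolated protein for inhibition of Glucose-dependent insulinotropic receptor (Rattus norvegicus), read by HTRF and cAMP accumulation (on this read-out higher numbers stand for an effect only at larger amounts of compound and lower numbers for an effect already at smaller amounts), the highest of the three numbers. Compound 1 `Cc1nc(S(C)(=O)=O)ccc1Oc1ncnc(OC2CCN(C(=O)OC(C)C)CC2)c1F` gives 142 nM and compound 3 `Cc1nc(S(C)(=O)=O)ccc1Oc1ncnc(OC2CCN(C(=S)OC(C)C)CC2)c1F` gives 1050 nM. The change to compound 4 `Cc1nc(S(C)(=O)=O)ccc1Oc1ncnc(OC2CCN(C(=O)C(F)(F)F)CC2)c1F` is a group of 4 heavy atoms (1 carbon, 3 fluorine; no ring) in place of a group of 5 heavy atoms (3 carbon, 1 oxygen, 1 fluorine; no ring), on a carbonyl carbon. Within the data shown here, no measured step swaps the whole carbonyl substituent for trifluoromethyl; the nearest are a 12-fold higher number from compound 1 to compound 2 (1.07 log units; beyond the scatter) and a 7.4-fold higher number from compound 1 to compound 3 (0.87 log units; beyond the scatter), while a 1.6-fold lower number from compound 2 to compound 3 (0.20 log units; within the scatter) lies within the scatter. All three measured compounds keep a carbamate or thiocarbamate on the ring nitrogen, so the trifluoromethyl outcome is uncertain. The fluorinated chain whose entry marked the step from compound 1 to compound 2 is absent from compound 4. On this basis compound 4 is expected to recover part of what was lost, a 3.4-fold lower number from compound 2 to compound 4 (0.53 log units; beyond the scatter). The estimate for compound 4 is 500 nM, range 100 nM to 3000 nM.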

Compound 4, half-maximal effective concentration: 880 nM
Compound 4: the middle estimate sits 1.8-fold (0.25 log units) below what was measured; the range from low to high includes it.
By their numbers in this assay, from the lowest: compound 1; then compounds 4, 3 and 2 (each within the scatter of the next).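

In this assay, trifluoromethyl in place of isopropoxy on the carbonyl carbon gives a 6.2-fold higher number from compound 1 to compound 4 (0.79 log units; beyond the scatter), so this position is also sensitive to a change that removes the carbamate oxygen. Trifluoromethyl brings no clear recovery from the fluorinated carbamate, with a 1.9-fold lower number from compound 2 to compound 4 (0.28 log units; within the scatter), and it cannot be told from the thiocarbamate, with a 1.2-fold lower number from compound 3 to compound 4 (0.08 log units; within the scatter). Among these four, only compound 1, with its isopropyl carbamate, stands apart from the others.

Nothing shown gives a reason for these results. On these data alone, whether methyl, cyclopropyl or a dimethylamino group on the carbonyl carbon would track isopropoxy or trifluoromethyl remains open.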